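From a 3-Fluorobenzyl to a 3,5-Dimethoxybenzyl Ether

The source may report more compounds than this note shows. Statements on the series, on what has been measured and on what is new or still open speak of the compounds shown alone.

Two compounds have been measured so far in a functional assay on MCF7 cells (Homo sapiens) for antiproliferative activity, read by sulforhodamine B assay, with a stated time of 72 h; a higher number here means a weaker inhibitor, a lower number a stronger inhibitor:

Compound 1 `FC(F)(F)c1ccc(CN2CCN(Cc3cc(-c4ccc(OCc5ccccc5Cl)cc4)on3)CC2)cc1` gives 2800 nM.
Compound 2 `Fc1cccc(COc2ccc(-c3cc(CN4CCN(Cc5ccc(C(F)(F)F)cc5)CC4)no3)cc2)c1` gives 2500 nM.

Compound 2 has the lower of the two numbers, but its nearest neighbour is compound 1, and the step of a 1.1-fold lower number from compound 1 to compound 2 (0.05 log units; within the scatter) lies within the scatter, so the two cannot be told apart on these data.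

Compound 3 `COc1cc(COc2ccc(-c3cc(CN4CCN(Cc5ccc(C(F)(F)F)cc5)CC4)no3)cc2)cc(OC)c1` has not yet been measured. It differs from compound 2 in one place: 3,5-dimethoxyphenyl in place of 3-fluorophenyl on a saturated chain carbon bound to an oxygen on an aromatic ring.

Going by the values given here, only one measured step bears on this change. It is a 1.1-fold lower number from compound 1 to compound 2 (0.05 log units; within the scatter), which also swapped one aromatic ring for another on the saturated chain carbon bound to an oxygen on an aromatic ring, and it stayed within the scatter. Among the compounds with values here, the change to compound 3 is larger, since the entering group brings two hydrogen-bond acceptors and more heavy atoms, and no measured pair shows what such an exchange does here. The expected step of no change at the digits printed from compound 2 to compound 3 (within the scatter) is therefore none beyond the scatter, with a wide range to allow for the unknown. Compound 3 is estimated at 2500 nM, between 900 nM and 7000 nM.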

Compound 3, half-maximal inhibitory concentration: 100 nM
Beside the measured number, compound 3's estimate is 25-fold (1.40 log units) above it, and the stated range ends above it.
By their numbers in this assay, from the lowest: compound 3; then compounds 2 and 1 (each within the scatter of the next).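

At the saturated chain carbon bound to an oxygen on an aromatic ring, the choice of aromatic ring can matter a great deal in this assay. Putting 3,5-dimethoxyphenyl in place of 3-fluorophenyl gives a 25-fold lower number from compound 2 to compound 3 (1.40 log units; beyond the scatter), and putting the same group in place of 2-chlorophenyl gives a 28-fold lower number from compound 1 to compound 3 (1.45 log units; beyond the scatter), whereas the exchange between the two halogen-bearing rings stayed within the scatter. Nothing shown here explains why the 3,5-dimethoxyphenyl ring gives so much lower a number.

On these data alone, it remains open whether the gain needs both methoxy groups or whether a single methoxy group on the ring would be enough. It is also unknown whether the oxygen atoms of those groups count, which methyl groups in their place could test, and whether ethoxy groups would keep, lose or extend the gain.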